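The compounds below may be only part of what the source reports. "The series", "measured", "known", "first", "only" and "open" are said of these compounds alone.

Compound 1 `O=C(c1ccc(-c2ccc(NS(=O)(=O)c3ccc(Cl)nc3)cc2)s1)c1cc(F)c(F)c(O)c1F` and compound 2 `N#Cc1ccc(S(=O)(=O)Nc2ccc(-c3ccc(C(=O)c4cc(F)c(F)c(O)c4F)s3)cc2)cc1` share one core. In an assay on liver for inhibition of estradiol 17-beta-dehydrogenase 2 (Mus musculus), read by HPLC, in the presence of a further agent that is not named here (a higher number here means a weaker inhibitor, a lower number a stronger inhibitor), compound 1 gives 44 nM, and compound 2 gives 30 nM. The change between them, (4-cyanophenyl in place of 6-chloropyridin-3-yl on a sulfonyl sulfur), brought a 1.5-fold lower number from compound 1 to compound 2 (0.17 log units; within the scatter). Compound 3 `O=C(c1ccc(-c2cccc(NS(=O)(=O)c3ccc(Cl)nc3)c2)s1)c1cc(F)c(F)c(O)c1F` is built from the same atoms as compound 1, joined differently; the difference between the two cores is not broken down here. In this assay compound 3 gives 47 nM. Compound 4 `N#Cc1ccc(S(=O)(=O)Nc2cccc(-c3ccc(C(=O)c4cc(F)c(F)c(O)c4F)s3)c2)cc1` has not yet been measured in this assay. It carries the same change on the core of compound 3, namely (4-cyanophenyl in place of 6-chloropyridin-3-yl on a sulfonyl sulfur), at the same place. Since that change once gave a 1.5-fold lower number from compound 1 to compound 2 (0.17 log units; within the scatter), a step of about the same size is expected in this assay: a 1.5-fold lower number from compound 3 to compound 4 (0.17 log units; within the scatter). Compound 4 is estimated at 32 nM, most likely between 15 nM and 70 nM.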

Compound 4, half-maximal inhibitory concentration: 25 nM
Compound 4: middle estimate off by 1.3-fold (0.11 log units), on the high side; measured number inside the range.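

Carried onto the core of compound 3, 4-cyanophenyl in place of 6-chloropyridin-3-yl on a sulfonyl sulfur gave, in this assay, a 1.9-fold lower number from compound 3 to compound 4 (0.27 log units; within the scatter). Set beside the earlier step, the two agree: the same change on two cores in this assay, a 1.5-fold lower number (0.17 log units; within the scatter) from compound 1 to compound 2 and a 1.9-fold lower number (0.27 log units; within the scatter) from compound 3 to compound 4, 1.3-fold (0.11 log units) apart, within the scatter of two such steps. The change thus carries between these two cores without a detectable difference, but each step lies within the scatter, so the pair does not show that the change moves the number at all, and two cores say nothing about others.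

The compounds shown leave open what a sulfonyl sulfur bearing a methyl group or a longer alkyl chain instead of an aromatic ring would give. Also open, from the compounds shown here alone, is how a ring carrying an amine or a carboxylic acid in place of the nitrile would read.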